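Swapping a Hydroxyl for Fluorine on a Hydrazone Aryl

This account rests on a few compounds, and the source may have more. Where it says the series, first, only, none or still open, it means among the compounds named here.

In a physicochemical assay for lipophilicity, measured as octanol-water partition (on this read-out higher numbers stand for higher lipophilicity and lower numbers for lower lipophilicity), compound 2 `O=C(COc1cccc2ccccc12)N/N=C/c1cccc(O)c1` gives 3.73 and stands lowest of the two measured compounds, while compound 1 `CCOc1ccc(/C=N/NC(=O)COc2cccc3ccccc23)cc1O` gives 3.82. Within the data shown here, the only measured step, a number 0.09 log units lower from compound 1 to compound 2 (within the scatter), concerns a different group and does not bear on the change here. Compound 3 `O=C(COc1cccc2ccccc12)N/N=C/c1ccc(F)cc1` differs by 4-fluorophenyl in place of 3-hydroxyphenyl on a carbon with a double bond to nitrogen. Dropping a hydroxyl and adding fluorine usually raises this kind of partition coefficient, so an upward step is expected, a number 0.77 log units higher from compound 2 to compound 3 (beyond the scatter). Compound 3 is therefore estimated at 4.5, with a range from 4.1 to 4.9.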

Compound 3, partition coefficient: 4.16
Compound 3: the middle estimate sits 0.34 log units above what was measured; measured number inside the range.
By their numbers in this assay, from the lowest: compounds 2 and 1 (each within the scatter of the next); then compound 3.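

Unlike the earlier step, which stayed within the scatter, this aryl swap on a carbon with a double bond to nitrogen gives a clear shift in this assay: a number 0.43 log units higher from compound 2 to compound 3 (beyond the scatter). The aryl group here is therefore a place where a single change can move the read-out, although the size of the step is modest. Nothing available explains the step.

Going by these compounds, the change removes the hydroxyl and adds the fluorine together, so the share of each stays open. Also open, on these data alone, is how a plain phenyl, or a phenyl bearing an amine or a carboxylic acid, would read here.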